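Halogen in place of methoxy on the shared core

This account rests on a few compounds, and the source may have more. Where it says the series, first, only, none or still open, it means among the compounds named here.

All numbers come from a functional assay on SW-620 cells (Homo sapiens) for cytotoxicity, read by colorimetric assay; a higher number here means a weaker inhibitor, a lower number a stronger inhibitor.

compound 1 `O=C(NO)c1ccc(CN2C(=O)/C(=C3\Nc4ccccc4\C3=N/O)c3cc(Br)ccc32)cc1`: 70 nM
compound 2 `O=C(/C=C/c1ccc(CN2C(=O)/C(=C3\Nc4ccccc4\C3=N/O)c3cc(Cl)ccc32)cc1)NO`: 80 nM
compound 3 `COc1ccc2c(c1)/C(=C1/Nc3ccccc3/C1=N\O)C(=O)N2Cc1ccc(C(=O)NO)cc1`: 40 nM

Compound 3 sits at the low end of the three numbers, but no gap separates it from the others beyond the scatter: the step of a 1.8-fold lower number from compound 1 to compound 3 (0.24 log units; within the scatter) is within the scatter, and compound 2 at 80 nM also lies within the scatter of compound 3.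

Compound 4 `O=C(NO)c1ccc(CN2C(=O)/C(=C3\Nc4ccccc4\C3=N/O)c3cc(Cl)ccc32)cc1` is the next member, not yet measured. It differs from compound 3 in one place: chloro in place of methoxy on an aromatic carbon. Within the data shown here, the only measured step at this position is the one from compound 1 to compound 3, a 1.8-fold lower number from compound 1 to compound 3 (0.24 log units; within the scatter), which was within the scatter; compound 4 walks that change back toward a halogen, so a number close to compound 3 is expected, and no step beyond the scatter is anticipated. Compound 2 also carries chloro at the same place and gives 80 nM, yet it differs from compound 4 in its hydroxamate side chain as well, so it is only a loose pointer. The expected step of a 1.6-fold higher number from compound 3 to compound 4 (0.21 log units; within the scatter) is small. Compound 4 is estimated at 65 nM, with a range of 30 nM to 140 nM.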

Compound 4, half-maximal inhibitory concentration: 60 nM
Compound 4: the middle estimate sits 1.1-fold (0.03 log units) above what was measured, and the stated range covers the measured number.
By their numbers in this assay, from the lowest: compounds 3, 4, 1 and 2 (each within the scatter of the next).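

In this assay, the position on the shared core now carries bromo, chloro and methoxy with the hydroxycarbamoyl side chain held constant, and chloro stays within the scatter of both other groups: chloro in place of methoxy gives a step of its own (a 1.5-fold higher number from compound 3 to compound 4 (0.18 log units; within the scatter)), as does chloro in place of bromo (a 1.2-fold lower number from compound 1 to compound 4 (0.07 log units; within the scatter)). Among these compounds, compound 4 also supplies the first pair that isolates the side chain, since compound 2 previously differed from every other compound in more than one place, and this change too stays within the scatter (a 1.3-fold lower number from compound 2 to compound 4 (0.12 log units; within the scatter)). Nothing among the data explains why these steps are so small.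

The compounds shown leave open whether this position stays as flat with an amine, a carboxylic acid or a longer alkoxy chain in place of methoxy, since only bromo, chloro and methoxy appear there. From the compounds shown here alone, the side-chain comparison also rests on a single pair carrying chloro, so whether it holds with bromo or methoxy on the core remains open.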